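Swapping Isopropyl for Aminomethyl on the Shared Core

A few compounds are considered here, and "the series" means these few. Any claim that something is new, unique, unknown or untested is made for them only; others in the source may bear on it.

Compound 1 `CC(C)c1csc(Nc2cccc3ccccc23)n1` stands second highest of the three numbers measured in an assay on CCRF-CEM cells for displacement of a labelled ligand from C-C chemokine receptor type 4 (Homo sapiens) (on this read-out lower numbers stand for stronger inhibition and higher numbers for weaker inhibition), where compound 1 gives 170 nM. Its nearest neighbour is compound 2 `CC(C)(C)c1csc(Nc2cccc3ccccc23)n1`, which gives 80 nM; the furthest is compound 3 `c1ccc(-c2csc(Nc3cccc4ccccc34)n2)cc1`, which gives 5500 nM. The measured steps on the same carbon of the shared core are a 2.1-fold lower number from compound 1 to compound 2 (0.33 log units; beyond the scatter) and a 32-fold higher number from compound 1 to compound 3 (1.51 log units; beyond the scatter), and between them a 69-fold higher number from compound 2 to compound 3 (1.84 log units; beyond the scatter).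

Compound 4 `NCc1csc(Nc2cccc3ccccc23)n1` differs from compound 1 by aminomethyl in place of isopropyl on an aromatic carbon. Among the measured compounds shown here, no measured step covers this change: the two steps that touch this carbon exchange one carbon group for another, and neither introduces a hydrogen-bond donor or acceptor. For the measured compounds named here, they show only that the group at this position sways this assay strongly, with a modest gain for tert-butyl and a large loss for phenyl. Compound 4 is therefore expected to give a weaker number than compound 1, with a step of a 3.5-fold higher number from compound 1 to compound 4 (0.55 log units; beyond the scatter) in this assay. The estimate for compound 4 is 600 nM, in the range 150 nM to 3000 nM.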

Compound 4, half-maximal inhibitory concentration: > 25000 nM
Compound 4: only a limit was reported; the forecaster's own chance of this, stated with the estimate: 5%; middle value at least 41-fold (1.61 log units) away from the limit.
By their numbers in this assay, from the lowest: compound 2; then compound 1; then compound 3. At a limit, above all of these: compound 4.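

In this assay compound 4 is reported only as a limit, not as a number: the limit of > 25000 nM in this assay, at which 1 of the 4 values shown sits. Even so, the steps can be read as lower bounds, an at least 140-fold higher number from compound 1 to compound 4 (2.16 log units; beyond the scatter) and an at least 310-fold higher number from compound 2 to compound 4 (2.49 log units; beyond the scatter), so aminomethyl, with its hydrogen-bond donor and acceptor, costs more on this carbon than the printed steps between carbon groups. Phenyl had given the highest number so far, yet aminomethyl lies past it too, with an at least 4.5-fold higher number from compound 3 to compound 4 (0.65 log units; beyond the scatter).

On these data alone, with only a limit, the full size of the loss stays unknown, and this single change does not separate the entering nitrogen from the shorter carbon group. The compounds shown leave open how a methyl, a hydroxymethyl or a longer chain ending in an amine would fare at this position.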